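A few compounds are considered here, and "the series" means these few. Any claim that something is new, unique, unknown or untested is made for them only; others in the source may bear on it.

Three compounds sharing one core were examined in an ADME assay on HepG2 cells (Homo sapiens) for cytotoxicity, read by CellTiter-Glo and resazurin assay, with a stated time of 72 h; on this read-out higher numbers stand for an effect only at larger amounts of compound and lower numbers for an effect already at smaller amounts. Compound 1 `CC(C)Oc1cccc(-c2ccc(C(=O)N(Cc3cccc(OCCCCCC(=O)O)c3)C(C)C)cc2)c1` gives in this assay only the limit > 26000 nM, so no number is known for it. Compound 2 `CC(C)N(Cc1cccc(OCCCCCC(=O)O)c1)C(=O)c1ccc(-c2ccsc2)cc1` gives in this assay only the limit > 26000 nM. Compound 3 `CC(C)N(Cc1cccc(OCCCCCC(=O)O)c1)C(=O)c1ccc(-c2cccc(O)c2)cc1` likewise gives in this assay only the limit > 26000 nM, and that is where it stands: at the edge of what the assay can report, with no number of its own. The step that the two limits leave unreadable from compound 1 to compound 3 and the step that the two limits leave unreadable from compound 2 to compound 3 therefore cannot be sized, because the limit of > 26000 nM in this assay, at which 3 of the 3 values shown sit, leaves both ends of each step out of reach.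

Compound 4 `COc1cc(F)cc(-c2ccc(C(=O)N(Cc3cccc(OCCCCCC(=O)O)c3)C(C)C)cc2)c1` differs from compound 3 by 3-fluoro-5-methoxyphenyl in place of 3-hydroxyphenyl on an aromatic carbon. The two measured steps leading into compound 3 give no readable size, so the step of a number no higher from compound 3 to compound 4 (the limit leaves the size open) is expected to be no readable change, with compound 4 most likely sitting at the same limit. Compound 4 is therefore estimated to give about 26000 nM in this assay, within 13000 nM and 60000 nM.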

Compound 4, half-maximal effective concentration: > 26000 nM
Compound 4: only a limit was reported (the forecaster's own chance of this, stated with the estimate: 85%); the middle value lies on the limit itself.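

Compound 4, like compound 1, compound 2 and compound 3, gives only a limit in this assay, so none of the steps to compound 4 can be read: the limit of > 26000 nM in this assay, at which 4 of the 4 values shown sit. The compounds shown leave open at what concentration any of them affects these cells, and whether exchanging the aromatic group on the shared core changes that concentration.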